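The compounds below may be only part of what the source reports. "The series", "measured", "known", "first", "only" and "open" are said of these compounds alone.

Compound 2, with the structure `COc1ccc2c(c1)CCC(Cc1ccccc1-c1ccccc1)C2=O`, gives the highest number among the two compounds measured: in an assay on CHO cells for inhibition of 1,25-dihydroxyvitamin D(3) 24-hydroxylase, mitochondrial (Homo sapiens) (on this read-out higher numbers stand for weaker inhibition and lower numbers for stronger inhibition), compound 2 gives 128000 nM. Its nearest neighbour is compound 1, `CCc1ccccc1CC1CCc2cc(OC)ccc2C1=O`, which in this assay gives 1920 nM. Among the compounds with values here, the one step that links them, a 67-fold higher number from compound 1 to compound 2 (1.82 log units; beyond the scatter), is a large one.

Compound 3, with the structure `COc1ccc2c(c1)CCC(Cc1ccccc1CCc1ccccc1)C2=O`, differs from compound 2 in one place: phenethyl in place of phenyl on an aromatic carbon. Within the data shown here, no measured step covers this change directly. The step from compound 1 to compound 2 shows how strongly the group on this aromatic carbon matters, and compound 1, which carries a short chain there, gives the lower number. Phenethyl carries a two-carbon chain between the ring and the aromatic carbon, so a move back towards the numbers of compound 1 seems possible, but the evidence is thin and the expected range is wide. Compound 3 is therefore expected to give a step of a 4.3-fold lower number from compound 2 to compound 3 (0.63 log units; beyond the scatter) in this assay. Compound 3 is estimated at 30000 nM, with a range from 5000 nM to 150000 nM.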

Compound 3, half-maximal inhibitory concentration: 25600 nM
Compound 3: the middle estimate sits 1.2-fold (0.07 log units) above what was measured, and the stated range covers the measured number.
By their numbers in this assay, from the lowest: compound 1; then compound 3; then compound 2.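

Placing the two-carbon chain of phenethyl on this aromatic carbon gives back only part of what phenyl loses: in this assay the change brings a 5.0-fold lower number from compound 2 to compound 3 (0.70 log units; beyond the scatter) and so shows that the outcome at this position depends on more than whether a second ring is present. Yet the recovery is incomplete, since adding phenyl to the end of the ethyl group of compound 1, in place of hydrogen on a saturated chain carbon, two bonds along the chain from an aromatic carbon, still brings a 13-fold higher number from compound 1 to compound 3 (1.12 log units; beyond the scatter) and leaves compound 3 well short of the ethyl compound. Among these three compounds, then, the two that carry a second ring both give higher numbers than compound 1, which has none, and no compound here goes against that.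

The compounds shown leave open how far a longer chain without a ring, such as propyl or butyl, would follow ethyl, and whether a three-carbon chain ending in phenyl would continue the fall seen with phenethyl. They also leave open how a ring-bearing chain ending in pyridine, or a chain ending in an amine or a carboxylic acid, would compare, and no measurement at hand explains the size of either step.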